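A Cyclopentyl Ring Replaces Butyl on the Sulfonyl Chain

The source may report more compounds than this note shows. Statements on the series, on what has been measured and on what is new or still open speak of the compounds shown alone.

Of the compounds shown here, three sharing one core have been measured in a functional assay, read by fluorescence and spectrophotometry, with a stated time of 1 h; a higher number here means that more compound is needed for the effect, a lower number that less compound is needed. Compound 1 `CCCCCCCS(=O)(=O)/C=C/c1ccc(O)c(O)c1` gives 7100 nM. Compound 2 `O=S(=O)(/C=C/c1ccc(O)c(O)c1)CCCC1CCCCC1` gives 7900 nM, and compound 3 `O=S(=O)(/C=C/c1ccc(O)c(O)c1)CCCCCCCCCO` gives 7500 nM. Compound 1 holds the lowest of the three numbers, yet its nearest neighbour lies at a 1.1-fold higher number from compound 1 to compound 3 (0.02 log units; within the scatter) and the furthest at a 1.1-fold higher number from compound 1 to compound 2 (0.05 log units; within the scatter), so the three cannot be told apart on these data.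

Compound 4 `O=S(=O)(/C=C/c1ccc(O)c(O)c1)CCCC1CCCC1` has not yet been measured in this assay. It departs from compound 1 by cyclopentyl in place of butyl on a saturated chain carbon, three bonds along the chain from a sulfonyl sulfur. For the measured compounds named here, the closest precedent is the exchange of butyl for cyclohexyl at the same place, which gave a 1.1-fold higher number from compound 1 to compound 2 (0.05 log units; within the scatter), a change that did not leave the scatter; the step of a 1.1-fold higher number from compound 1 to compound 3 (0.02 log units; within the scatter), at a different place along the chain, likewise stayed flat. Because a 1.1-fold higher number from compound 1 to compound 2 (0.05 log units; within the scatter) stayed within the scatter with a six-membered ring, a five-membered ring at the same place is expected to behave alike, with no step beyond the scatter in either direction. Compound 4 is therefore estimated at about 7400 nM, between 3700 nM and 15000 nM. That estimate implies a 1.0-fold higher number from compound 1 to compound 4 (0.02 log units; within the scatter), expected to be no more than the usual scatter.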

Compound 4, half-maximal effective concentration: 6300 nM
Estimate against measurement, compound 4: 1.2-fold (0.07 log units) above, within the range that was stated.
By their numbers in this assay, from the lowest: compounds 4, 1, 3 and 2 (each within the scatter of the next).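

In this assay, the exchange of butyl for cyclopentyl on a saturated chain carbon, three bonds along the chain from a sulfonyl sulfur, gives a 1.1-fold lower number from compound 1 to compound 4 (0.05 log units; within the scatter) and so adds a five-membered non-aromatic ring of carbon only to the groups that leave the number within the scatter. The two ring sizes can now be set directly against each other, and that step, a 1.3-fold lower number from compound 2 to compound 4 (0.10 log units; within the scatter), also stays within the scatter, as does the exchange for the hydroxyl-bearing chain, a 1.2-fold lower number from compound 3 to compound 4 (0.08 log units; within the scatter), so the open chain, both rings and the 6-hydroxyhexyl group cannot be told apart at this place, and none of the four compounds goes against that. Nothing available here accounts for this flatness.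

The compounds shown carry only carbon chains, rings of carbon and a single hydroxyl at this place, so they leave open whether an amine, a carboxylic acid or a phenyl ring there would move the number beyond the scatter. They also leave open whether a chain much shorter than any of these would stay as flat.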